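Lengthening a methyl group to an ethyl group

The compounds below may be only part of what the source reports. "The series", "measured", "known", "first", "only" and "open" are said of these compounds alone.

Measured in a functional assay on V79 cells (Cricetulus griseus) for cytotoxicity, read by colony formation; a higher number here means a weaker inhibitor, a lower number a stronger inhibitor:
compound 1 `CCNCC1CCN(c2c(F)cc3c(=O)c(C(=O)O)cn(C4CC4)c3c2Cl)C1`: 11 ug/mL; 11 ug/mL; < 11 ug/mL (3 entries)
compound 2 `Nc1c(F)c(N2CCC(N)C2)cc2c1c(=O)c(C(=O)O)cn2C1CC1`: 54 ug/mL
compound 3 `Cc1c(F)c(N2CCC(N)C2)cc2c1c(=O)c(C(=O)O)cn2C1CC1`: 14 ug/mL

Of the two compounds with a single entry, compound 3 has the lower number, 14 ug/mL. Within the data shown here, the only measured step, a 3.9-fold lower number from compound 2 to compound 3 (0.59 log units; beyond the scatter), puts methyl in place of amino on an aromatic carbon.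

Compound 4 `CCc1c(F)c(N2CCC(N)C2)cc2c1c(=O)c(C(=O)O)cn2C1CC1` differs from compound 3 by methyl in place of hydrogen on a saturated chain carbon bound to an aromatic carbon, so methyl becomes ethyl. Among the measured compounds shown here, no measured step makes this exact change, and the modest step above is only a loose guide. From the compounds shown here alone, no step beyond the scatter is therefore expected in this assay, and the direction stays open. The estimated step is a 1.1-fold higher number from compound 3 to compound 4 (0.06 log units; within the scatter). The estimate for compound 4 is 16 ug/mL, with an expected range of 7 ug/mL to 40 ug/mL.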

Compound 4, half-maximal inhibitory concentration: 46 ug/mL
For compound 4 the middle estimate is 2.9-fold (0.46 log units) below the measured one; measured number outside the range, above it.
By their numbers in this assay, from the lowest: compound 3; then compounds 4 and 2 (each within the scatter of the next).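

In this assay, a single added methyl on this group is enough to matter: going from methyl to ethyl gives a 3.3-fold higher number from compound 3 to compound 4 (0.52 log units; beyond the scatter). Ethyl in place of amino gives a 1.2-fold lower number from compound 2 to compound 4 (0.07 log units; within the scatter), so among these three groups on this aromatic carbon, only methyl stands apart, and a carbon chain as such does not secure the lower number. Nothing measured here accounts for this difference. From the compounds shown here alone, whether a longer chain such as propyl would follow ethyl, and where a methoxy group on this carbon would fall, stays open.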